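A few compounds are considered here, and "the series" means these few. Any claim that something is new, unique, unknown or untested is made for them only; others in the source may bear on it.

Compound 1 `O=[N+]([O-])c1ccc(-c2nnc(-c3cccnc3)n2Nc2nc3ccc(F)cc3s2)cc1` in an ADME assay on MT4 cells (Homo sapiens) for cytotoxicity, read by MTT assay, with a stated time of 5 days (a higher number here means that more compound is tolerated, a lower number that less compound is tolerated), gives >= 108 ug/mL, a limit of the assay.
Compound 2 `O=[N+]([O-])c1ccc(-c2nnc(-c3cccnc3)n2Nc2nc3ccc(Br)cc3s2)cc1` gives 13.2 ug/mL.
Compound 3 `O=[N+]([O-])c1ccc(-c2nnc(-c3cccnc3)n2Nc2nc3ccc([N+](=O)[O-])cc3s2)cc1` gives 50.8 ug/mL.

Compound 1 stands at the limit (the limit of >= 108 ug/mL in this assay, at which 1 of the 3 values shown sits); no number is known for it, only that it tolerates the most compound of the three. Compound 4 `Fc1ccc2nc(Nn3c(-c4ccc(Cl)cc4)nnc3-c3cccnc3)sc2c1` differs from it by chloro in place of nitro on an aromatic carbon. Among the compounds with values here, none of the measured steps changes this group: an at least 8.1-fold lower number from compound 1 to compound 2 (0.91 log units; beyond the scatter) and an at least 2.1-fold lower number from compound 1 to compound 3 (0.32 log units; beyond the scatter) alter the substituent on the other ring, and a 3.8-fold higher number from compound 2 to compound 3 (0.59 log units; beyond the scatter) compares nitro with a halogen there, with the nitro compound giving the higher number. A modest drop from the limit is therefore expected, an at least 1.8-fold lower number from compound 1 to compound 4 (0.25 log units; that floor lies within the scatter), and compound 4 is estimated at 60 ug/mL, within 20 ug/mL to 150 ug/mL.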

Compound 4, half-maximal cytotoxic concentration: 92.9 ug/mL
Compound 4: middle estimate off by 1.5-fold (0.19 log units), on the low side; the measured number falls inside the stated range.
By their numbers in this assay, from the lowest: compound 2; then compounds 3 and 4 (each within the scatter of the next). At a limit, above all of these: compound 1.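

Within the data shown here, compounds 1 to 3 all carry nitro at this position, so the 4-nitrophenyl to 4-chlorophenyl change shows for the first time what replacing that group does with the fluoro substituent kept. In this assay the change gives an at least 1.1-fold lower number from compound 1 to compound 4 (0.06 log units; that floor lies within the scatter). Its true size cannot be read because compound 1 sits at a limit: the limit of >= 108 ug/mL in this assay, at which 1 of the 4 values shown sits.

As far as these compounds go, whether chloro and nitro differ at all here stays open. So does how an amine or a carboxylic acid at this position would fare, or chloro paired with bromo on the other ring.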